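A few compounds are considered here, and "the series" means these few. Any claim that something is new, unique, unknown or untested is made for them only; others in the source may bear on it.

Of the compounds shown here, three sharing one core have been tested in a functional assay on the whole organism (strain albino) for inhibition, with Rattus norvegicus as the target, read by paw edema, with stated times of 30 min and 2 h, at a dose of 0.28 mmol/kg by the oral route; a higher number here means more inhibition at the dose given (going by the name of the read-out), a lower number less inhibition. Compound 1 `C=CCn1c(SCC(=O)Nc2ccc(C(C)=O)cc2)nnc1-c1ccc(OC)c(OC)c1` gives 57% in this assay. Compound 2 `CCn1c(SCC(=O)Nc2ccc(C(C)=O)cc2)nnc1-c1cc(OC)c(OC)c(OC)c1` gives 50%. Compound 3 `COc1cc(-c2nnc(SCC(=O)Nc3ccc(C(C)=O)cc3)n2-c2ccccc2)cc(OC)c1OC` gives 54%, which places it second highest of the three numbers, with compound 1 nearest and compound 2 furthest, both within the scatter. For the measured compounds named here, the one change that alters only the group on the aromatic nitrogen, a number 4 percentage points higher from compound 2 to compound 3 (within the scatter), stayed within the scatter.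

Compound 4 `C=CCn1c(SCC(=O)Nc2ccc(C(C)=O)cc2)nnc1-c1cc(OC)c(OC)c(OC)c1` differs from compound 3 in that place: allyl in place of phenyl on an aromatic nitrogen. Going by the values given here, no measured pair shows this exact exchange. The phenyl-for-ethyl step just named is the nearest guide, and it was small; compound 1, which also carries allyl on that nitrogen, and compound 2 show values that sit within the scatter of each other. Compound 4 is therefore expected to give 52% in this assay, within 42% to 62%. The expected step of a number 2 percentage points lower from compound 3 to compound 4 (within the scatter) is estimated to lie within the scatter.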

Compound 4, a percentage reported as inhibition, in the whole organism at one dose (the size of the read-out at that dose, not a potency): 54%
For compound 4 the middle estimate is 2 percentage points below the measured one; the measured number falls inside the stated range.
By their numbers in this assay, from the lowest: compounds 2, 3, 4 and 1 (each within the scatter of the next).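

In this assay, allyl in place of phenyl on the aromatic nitrogen gives no change at the digits printed from compound 3 to compound 4 (within the scatter), so an open chain with one double bond reads the same here as a six-membered aromatic ring. Vinyl in place of methyl on the saturated chain carbon bound to that nitrogen gives a number 4 percentage points higher from compound 2 to compound 4 (within the scatter), which puts ethyl, allyl and phenyl within the scatter of one another where the 3,4,5-trimethoxyphenyl group is present. For the compounds shown here, with allyl held in place, methoxy in place of hydrogen on an aromatic carbon gives a number 3 percentage points lower from compound 1 to compound 4 (within the scatter), the first direct reading of that exchange, and it also stays within the scatter.

No data here explain this flat response. Still open, going by these compounds, is whether a carboxylic acid, an amine or a longer chain such as hexyl on that nitrogen would move the inhibition of paw edema beyond the scatter.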